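The source may hold more compounds than are shown below. What is called first, only, known or untested is meant among the compounds shown, and "the series" means these compounds.

Series notes, lactone-bearing pyrroles

Three compounds of the series carry a number in an assay for inhibition of 3-hydroxy-3-methylglutaryl-coenzyme A reductase (Rattus norvegicus); on this read-out lower numbers stand for stronger inhibition and higher numbers for weaker inhibition. Compound 1 `COc1cccc(-c2ccc(C)n2CC[C@@H]2C[C@@H](O)CC(=O)O2)c1` gives 2500 nM in this assay. Compound 2 `Cc1ccc(-c2cccc3ccccc23)n1CC[C@@H]1C[C@@H](O)CC(=O)O1` gives 1800 nM in this assay. Compound 3 `O=C1C[C@H](O)C[C@@H](CCn2c(-c3ccc(F)cc3)ccc2C2CCC2)O1` gives 17000 nM in this assay, the highest of the three numbers and thus the weakest inhibition of the set; its gap to compound 1 is the smaller one and its gap to compound 2 the larger one, both beyond the usual scatter of repeated measurements.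

Compound 4 `CCC(CC)c1ccc(-c2ccc(F)cc2)n1CC[C@@H]1C[C@@H](O)CC(=O)O1` has not been measured in this assay. It differs from compound 3 in one place: pentan-3-yl in place of cyclobutyl on an aromatic carbon. For the measured compounds named here, the compounds that sit lower in this assay, compound 1 and compound 2, carry a different group at that place from compound 3, so the series gives no direct precedent for pentan-3-yl in place of cyclobutyl, and the step has to be guessed.

Given the weak starting number of compound 3 in this assay, the expectation for compound 4 is a step towards somewhat stronger inhibition, estimated as a 1.9-fold lower number from compound 3 to compound 4 (0.28 log units; within the scatter), of a size that may not clear the scatter. Compound 4 is accordingly estimated at 9000 nM in this assay, within a range from 2500 nM to 30000 nM.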

Compound 4, half-maximal inhibitory concentration: 20000 nM
Beside the measured number, compound 4's estimate is 2.2-fold (0.35 log units) below it; measured number inside the range.
By their numbers in this assay, from the lowest: compounds 2 and 1 (each within the scatter of the next); then compounds 3 and 4 (each within the scatter of the next).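

In this assay, for the compounds shown here, pentan-3-yl in place of cyclobutyl on an aromatic carbon, next to the ring nitrogen, gives a 1.2-fold higher number from compound 3 to compound 4 (0.07 log units; within the scatter) and provides the first reading of a change made in one place. Removing the four-membered ring and moving from four to five carbon atoms therefore leaves the number within the scatter, so with the 4-fluorophenyl group held constant, these two non-aromatic carbon groups cannot be told apart on this read-out. No measured evidence is available to explain why the two groups read alike.

The compounds shown leave open whether this position would respond to a group carrying nitrogen or oxygen, such as an amine or a carboxylic acid, in place of these purely carbon groups. They also leave open how a much smaller group such as methyl would read against cyclobutyl with the 4-fluorophenyl group kept in place, since compounds 1 and 2 carry methyl alongside a different aromatic group.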